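The source may hold more compounds than are shown below. What is called first, only, known or untested is meant among the compounds shown, and "the series" means these compounds.

Measured compounds in a functional assay on MDA-MB-231 cells (Homo sapiens) for cytotoxicity, read by MTT assay, with a stated time of 48 h; on this read-out higher numbers stand for weaker inhibition and lower numbers for stronger inhibition:
compound 1, `COc1cc(/C=C/c2ccc(OCCCCC(=O)NO)cc2)cc(OC)c1`, 4210 nM
compound 2, `COc1cc(/C=C/c2ccc(OCCCCCC(=O)NO)cc2)cc(OC)c1`, 3560 nM
compound 3, `COc1cc(/C=C/c2ccc(OCCCCCCC(=O)NO)cc2)cc(OC)c1`, 780 nM

Compound 3 gives the lowest number of the three in this assay; its steps to the others, a 4.6-fold lower number from compound 2 to compound 3 (0.66 log units; beyond the scatter) and a 5.4-fold lower number from compound 1 to compound 3 (0.73 log units; beyond the scatter), both lie beyond the scatter, while a 1.2-fold lower number from compound 1 to compound 2 (0.07 log units; within the scatter) does not.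

Compound 4, `COc1cc(/C=C/c2ccc(OCCc3cn(CC(=O)NO)nn3)cc2)cc(OC)c1`, has not yet been measured in this assay. Relative to compound 3 the change is 1-((hydroxycarbamoyl)methyl)-1H-1,2,3-triazol-4-yl in place of 4-(hydroxycarbamoyl)butyl on a saturated chain carbon, two bonds along the chain from an oxygen on an aromatic ring. The measured steps all concern lengthening of an open chain carrying the hydroxycarbamoyl group, and the two that reach compound 3 are modest and in the direction of lower numbers. None of them involves a ring in the chain, so they bear on compound 4 only loosely. Going by the values given here, the chain of compound 4 is of comparable reach to that of compound 3 but of a different kind, and no measured pair tells what that does in this assay. Compound 4 is therefore expected to land near compound 3, with wide uncertainty, giving an expected step of a 1.9-fold higher number from compound 3 to compound 4 (0.28 log units; within the scatter). The estimate for compound 4 in this assay is 1500 nM, with a range of 400 nM to 6000 nM.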

Compound 4, half-maximal inhibitory concentration: 6520 nM
For compound 4 the middle estimate is 4.3-fold (0.64 log units) below the measured one; the whole stated range lies below it.
By their numbers in this assay, from the lowest: compound 3; then compounds 2, 1 and 4 (each within the scatter of the next).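

In this assay, 1-((hydroxycarbamoyl)methyl)-1H-1,2,3-triazol-4-yl on this saturated chain carbon does not keep the low number given by 4-(hydroxycarbamoyl)butyl, with an 8.4-fold higher number from compound 3 to compound 4 (0.92 log units; beyond the scatter). Set against the two shorter open chains, the ring-bearing chain cannot be told apart, with a 1.8-fold higher number from compound 2 to compound 4 (0.26 log units; within the scatter) and a 1.5-fold higher number from compound 1 to compound 4 (0.19 log units; within the scatter), so at this place the kind of chain counts and not only its reach. No measurement at hand accounts for the loss.

Going by these compounds, it remains open whether the five-membered aromatic ring itself or the short methyl link from that ring to the hydroxycarbamoyl group sets this result. A longer chain between the ring and the hydroxycarbamoyl group would separate the two, and an open chain longer than 4-(hydroxycarbamoyl)butyl would show whether the trend among the open chains continues.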